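From Compound 2 to Its Chloro Counterpart, Compound 3

The source may hold more compounds than are shown below. What is called first, only, known or untested is meant among the compounds shown, and "the series" means these compounds.

Measured so far in a functional assay on HepG2 cells (Homo sapiens) for cytotoxicity, read by MTT assay, with a stated time of 24 h; a lower number here means a stronger inhibitor, a higher number a weaker inhibitor:
- compound 1 `O=C1/C(=C/c2cccnc2)CN(S(=O)(=O)c2ccccc2)C/C1=C\c1ccccc1C(F)(F)F`: 5370 nM
- compound 2 `O=C1/C(=C/c2ccncc2)CN(S(=O)(=O)c2ccccc2)C/C1=C\c1ccccc1C(F)(F)F`: 7020 nM

Among the compounds with values here, only two compounds have been measured in this assay, so the standing of compound 2 is easily told. Within the data shown here, its value of 7020 nM cannot be separated from that of its only neighbour. Among the measured compounds shown here, the one measured step is a 1.3-fold higher number from compound 1 to compound 2 (0.12 log units; within the scatter), and it consists of pyridin-4-yl in place of pyridin-3-yl.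

Compound 3 `O=C1/C(=C/c2ccncc2)CN(S(=O)(=O)c2ccc(Cl)cc2)C/C1=C\c1ccccc1C(F)(F)F` keeps the pyridin-4-yl group of compound 2 and changes the other end of the molecule. It has chloro in place of hydrogen on an aromatic carbon, para to a large group, so that phenylsulfonyl becomes (4-chlorophenyl)sulfonyl (chloro in place of hydrogen on an aromatic carbon). For the measured compounds named here, the measured step bears on this change only indirectly, since it lies elsewhere in the molecule and no measured pair varies the phenylsulfonyl group. Going by the values given here, it shows only that one small change left the number within the scatter. The expected step is a 1.3-fold lower number from compound 2 to compound 3 (0.11 log units; within the scatter), and nothing beyond the scatter is anticipated. For compound 3 the estimated value is 5500 nM, with an expected range from 2000 nM to 13000 nM.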

Compound 3, half-maximal inhibitory concentration: 7190 nM
Compound 3: the middle estimate sits 1.3-fold (0.12 log units) below what was measured; the measured number falls inside the stated range.
By their numbers in this assay, from the lowest: compounds 1, 2 and 3 (each within the scatter of the next).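

In this assay, within the data shown here, the phenylsulfonyl end of the molecule is varied for the first time, and chloro in place of hydrogen, on an aromatic carbon para to a large group, gives a 1.0-fold higher number from compound 2 to compound 3 (0.01 log units; within the scatter) with the pyridin-4-yl group held constant. Read with the earlier swap at the other end of the molecule, a 1.3-fold higher number from compound 1 to compound 2 (0.12 log units; within the scatter) as well, this means that each of the two single changes shown, at two separate places, stays within the scatter, so these three compounds cannot be ranked in this assay. Nothing at hand explains why the chloro step is this small, and no supporting measurement bears on it.

With only hydrogen and chloro shown at this place, it remains open whether a methoxy group, an amine or a carboxylic acid there would also stay within the scatter. Also open, going by these compounds, is whether the same chloro change would read alike on the pyridin-3-yl compound, and whether replacing the trifluoromethyl group with a nitrile would move the number at all.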